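Swapping a fluorophenyl for a methoxymethyl-pyridinyl on the oxadiazole

The compounds below may be only part of what the source reports. "The series", "measured", "known", "first", "only" and "open" are said of these compounds alone.

Three compounds share a core and were tested in an assay on T-REx-293 cells for inhibition of potassium channel subfamily T member 1 (Homo sapiens), read by patch clamp; a lower number here means a stronger inhibitor, a higher number a weaker inhibitor. Compound 1, `Cc1cccc(-c2noc([C@H](C)NC(=O)c3cc(C4CC4)nn3C)n2)c1`, gives 167 nM. Compound 2, `Cc1cccc(-c2noc([C@H](C)NC(=O)c3cc(C4CC4)n(C)n3)n2)c1`, reaches only the assay limit, > 30000 nM, which is a limit rather than a number (the limit of > 30000 nM in this assay, at which 1 of the 3 values shown sits). Compound 3, `C[C@H](NC(=O)c1cc(C(F)(F)F)nn1C)c1nc(-c2cccc(F)c2)no1`, gives 136 nM, the lowest of the two numbers, though its gap to compound 1 lies within the usual scatter. Compound 4, `COCc1cc(-c2noc([C@H](C)NC(=O)c3cc(C(F)(F)F)nn3C)n2)ccn1`, has not yet been measured; it differs from compound 3 by 2-(methoxymethyl)pyridin-4-yl in place of 3-fluorophenyl on an aromatic carbon. Among the compounds with values here, no measured pair isolates this change, so the direction is uncertain; a modest weakening is expected, the step of a 2.2-fold higher number from compound 3 to compound 4 (0.34 log units; beyond the scatter) being the estimate. Compound 4 is thus expected to give 300 nM, from 80 nM to 1500 nM.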

Compound 4, half-maximal inhibitory concentration: 322 nM
The estimate for compound 4 lay 1.1-fold (0.03 log units) below the measured number; low and high end bracket the measured number.
By their numbers in this assay, from the lowest: compounds 3, 1 and 4 (each within the scatter of the next, the first and the last beyond it). At a limit, above all of these: compound 2.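

Within the data shown here, replacing 3-fluorophenyl with 2-(methoxymethyl)pyridin-4-yl on this aromatic carbon gives a 2.4-fold higher number from compound 3 to compound 4 (0.37 log units; beyond the scatter) in this assay, the first pair to isolate a change at this position. A ring nitrogen and a methoxymethyl chain, which bring hydrogen-bond acceptors absent from 3-fluorophenyl, thus cost only a modest step here and leave inhibition in place. Nothing measured here bears on what lies behind the step.

The ring nitrogen and the methoxymethyl chain enter together, and the compounds shown do not separate them. Also open, as far as these compounds go, is how an unsubstituted pyridin-4-yl or a phenyl ring bearing an amine would read at this position.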